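The source may report more compounds than this note shows. Statements on the series, on what has been measured and on what is new or still open speak of the compounds shown alone.

In a functional assay on HepG2 cells (Homo sapiens) for inhibition, with a stated time of 72 h (a higher number here means a weaker inhibitor, a lower number a stronger inhibitor), compound 1 `COc1ccc(NC(=O)Nc2nc(Sc3c[nH]c4ccccc34)cc(N3CCCCC3)n2)cc1` gives 17100 nM and compound 2 `O=C(Nc1ccc(Cl)cc1)Nc1nc(Sc2c[nH]c3ccccc23)cc(N2CCCC2)n1` gives 7870 nM as the lower of these two numbers, which marks it as the stronger inhibitor of the pair. Compound 3 `O=C(Nc1ccc(Cl)cc1)Nc1nc(Sc2c[nH]c3ccccc23)cc(N2CCCCC2)n1` differs from compound 2 by piperidin-1-yl in place of pyrrolidin-1-yl on an aromatic carbon and by nothing else. Among the measured compounds shown here, no measured pair isolates this change. Compound 1 at 17100 nM also carries piperidin-1-yl but differs in a second place as well, so only a small rise in this assay is expected, an estimated 1.3-fold higher number from compound 2 to compound 3 (0.10 log units; within the scatter) that probably stays within the scatter. Compound 3 is estimated at 10000 nM within a range of 4500 nM to 20000 nM in this measurement.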

Compound 3, half-maximal inhibitory concentration: 14800 nM
For compound 3 the middle estimate is 1.5-fold (0.17 log units) below the measured one; low and high end bracket the measured number.
By their numbers in this assay, from the lowest: compounds 2, 3 and 1 (each within the scatter of the next, the first and the last beyond it).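

In this assay, piperidin-1-yl in place of pyrrolidin-1-yl gives a 1.9-fold higher number from compound 2 to compound 3 (0.27 log units; within the scatter) on this carbon of the shared core, so this single change gives no clear difference between the two rings. Chloro in place of methoxy gives a 1.2-fold lower number from compound 1 to compound 3 (0.06 log units; within the scatter) with piperidin-1-yl held constant, so this swap also gives no clear difference. No measured information bears on these results.

Morpholin-4-yl or an open-chain dimethylamino group at this position remains untested among the compounds shown. Going by these compounds, whether either would shift the number beyond the scatter stays open.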